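Swapping 4-methylphenyl for 4-methylbenzyl on a sulfur

The compounds below may be only part of what the source reports. "The series", "measured", "known", "first", "only" and "open" are said of these compounds alone.

Measured so far in a functional assay on DU-145 cells (Homo sapiens) for inhibition, read by trypan blue exclusion, with a stated time of 96 h; a lower number here means a stronger inhibitor of growth, a higher number a weaker inhibitor of growth:
compound 1 `Cc1ccc(CS/C(=C/c2ccc(O)cc2)C(=O)c2ccc(Cl)cc2)cc1`: 10000 nM
compound 2 `Cc1ccc(CS/C(=C/c2sccc2C)C(=O)c2ccc(Cl)cc2)cc1`: 10000 nM
compound 3 `Cc1ccc(S/C(=C/c2c[nH]c3ccc(Cl)cc23)C(=O)c2ccc(Cl)cc2)cc1`: 1000 nM

Of these three, compound 3 has the lowest number, and both others lie beyond the scatter above it. Compound 4 `Cc1ccc(CS/C(=C/c2c[nH]c3ccc(Cl)cc23)C(=O)c2ccc(Cl)cc2)cc1` differs from compound 3 in one place: 4-methylbenzyl in place of 4-methylphenyl on a sulfur, with 4-methylbenzyl in place of 4-methylphenyl on a sulfur. Among the measured compounds shown here, no measured step makes this change. For the measured compounds named here, the one measured step, no change at the digits printed from compound 1 to compound 2 (within the scatter), concerns another group. Compound 1 at 10000 nM and compound 2 at 10000 nM both carry 4-methylbenzyl, but they also differ from compound 3 elsewhere, so they offer only weak guidance. A modest rise is therefore expected, as the estimated step of a 2.5-fold higher number from compound 3 to compound 4 (0.40 log units; beyond the scatter) shows. Compound 4 is estimated at 2500 nM, with an expected range from 600 nM to 10000 nM.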

Compound 4, concentration for 50% growth inhibition: 1000 nM
Compound 4: the middle estimate sits 2.5-fold (0.40 log units) above what was measured; low and high end bracket the measured number.
By their numbers in this assay, from the lowest: compounds 3 and 4 (each within the scatter of the next); then compounds 1 and 2 (each within the scatter of the next).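

In this assay, the sulfur accepts 4-methylbenzyl in place of 4-methylphenyl with the 5-chloro-1H-indol-3-yl group present, showing no change at the digits printed from compound 3 to compound 4 (within the scatter). With 4-methylbenzyl held constant, 5-chloro-1H-indol-3-yl on the double-bonded chain carbon gives a 10-fold lower number from compound 2 to compound 4 (1.00 log units; beyond the scatter) and a 10-fold lower number from compound 1 to compound 4 (1.00 log units; beyond the scatter), so this position separates these compounds. No evidence bears on why the sulfur change left the number unmoved or why the chain-carbon changes lowered it. From the compounds shown here alone, it remains open whether this tolerance on the sulfur extends to a longer chain, or to a group carrying an amine or a carboxylic acid. The compounds shown also do not tell whether 4-methylphenyl on the sulfur would behave alike with 4-hydroxyphenyl or 3-methylthiophen-2-yl on the chain carbon.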